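Swapping methylamino for hydroxy on a pyridazinone side chain

The source may hold more compounds than are shown below. What is called first, only, known or untested is meant among the compounds shown, and "the series" means these compounds.

Measured compounds:
- compound 1, `CNC(=O)CCn1nc(-c2ccccc2)ccc1=O`: 3.5%
- compound 2, `Cc1ccc(=O)n(CC(=N)S)n1`: 31.5%

Of the compounds shown here, two have been tested in a functional assay on the whole organism (stomach) for inhibition, with Rattus norvegicus as the target, at a dose of 100 mg/kg by the intraduodenal route; a lower number here means less inhibition, a higher number more inhibition at the dose given (going by the name of the read-out). Compound 1 gives 3.5% in this assay, the lowest of the two numbers. Compound 2 shares no simple one-place relation to compound 1. In this assay compound 2 gives 31.5%, a number that lies beyond the scatter above that of compound 1.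

Compound 3, `O=C(O)CCn1nc(-c2ccccc2)ccc1=O`, is not yet measured. It differs from compound 1 in one place: hydroxy in place of methylamino on a carbonyl carbon. Going by the values given here, nothing among the measured compounds shows how such a change plays out in this assay, so there is no comparable step to lean on. With compound 1 sitting at 3.5%, the expected step of a number 4.5 percentage points higher from compound 1 to compound 3 (within the scatter) is small, with no direction that can be claimed beyond the scatter. Compound 3 is therefore estimated at 8% in this assay, within a range from 0% to 30%.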

Compound 3, a percentage reported as inhibition, in the whole organism at one dose (the size of the read-out at that dose, not a potency): 26.1%
Compound 3: the middle estimate sits 18.1 percentage points below what was measured; the measured number falls inside the stated range.
By their numbers in this assay, from the lowest: compound 1; then compounds 3 and 2 (each within the scatter of the next).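

Compound 1 and compound 3 give the first view of a single change at this position. In this assay, putting hydroxy in place of methylamino on the carbonyl carbon gives a number 22.6 percentage points higher from compound 1 to compound 3 (beyond the scatter), so the read-out at the end of this side chain is sensitive to which group sits there, at least on this core. The computed counts do not separate the two groups by hydrogen-bond donors, hydrogen-bond acceptors or net charge, although methylamino has one more heavy atom than hydroxy, and nothing measured here explains the rise in inhibition.

As far as these compounds go, with a single pair, it remains open whether the gain comes from having hydroxy on the carbonyl carbon or simply from losing methylamino, a question that groups such as amino or methoxy in the same place could help to answer. From the compounds shown here alone, it is also open whether 2-carboxyethyl is the best chain length, which a longer chain such as 3-carboxypropyl or a shorter one such as carboxymethyl could test, and whether the same swap has a similar effect on another core.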